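Piperidinylmethyl aryl esters, chromone isomer step

The source may hold more compounds than are shown below. What is called first, only, known or untested is meant among the compounds shown, and "the series" means these compounds.

Measured so far:
compound 1 `COc1ccc(OCCCCCN2CCCC(COC(=O)c3ccccc3N3C(=O)CC(C)C3=O)C2)cc1`, 14500 nM
compound 2 `COc1ccc(OCCCCCN2CCCC(COC(=O)c3cc(=O)c4ccccc4o3)C2)cc1`, 10200 nM
compound 3 `CN1CCCC(COC(=O)c2ccccc2-c2ccccc2)C1`, 6920 nM

In an in vitro functional assay on HEK ts201 cells for antagonist activity at Neuronal acetylcholine receptor; alpha4/beta2 (Homo sapiens), read by fluorescence and calcium flux (a higher number here means a weaker inhibitor, a lower number a stronger inhibitor), compound 1 gives 14500 nM, compound 2 gives 10200 nM and compound 3 gives 6920 nM. Compound 2 stands second highest of the three numbers; its nearest neighbour is compound 1 and its furthest is compound 3, and both gaps lie within the scatter, so no order among the three can be read from these data.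

Compound 4 `COc1ccc(OCCCCCN2CCCC(COC(=O)c3coc4ccccc4c3=O)C2)cc1` has not been measured. It differs from compound 2 as follows: a group of 11 heavy atoms (9 carbon, 2 oxygen; one six-membered aromatic ring of carbon only, one six-membered aromatic ring with 1 hetero atom) in place of a group of 11 heavy atoms (9 carbon, 2 oxygen; one six-membered aromatic ring of carbon only, one six-membered aromatic ring with 1 hetero atom), on a carbonyl carbon. Going by the values given here, the same atoms are joined differently, and no step between measured compounds resembles this change, so nothing beyond the scatter is expected in either direction. Compound 4 is expected to give 10000 nM (range 4000 nM to 25000 nM) in this assay. The expected step of a 1.0-fold lower number from compound 2 to compound 4 (0.01 log units; within the scatter) is essentially none beyond the scatter.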

Compound 4, half-maximal inhibitory concentration: 10000 nM
Estimate against measurement, compound 4: no gap at the digits printed; the measured number falls inside the stated range.
By their numbers in this assay, from the lowest: compounds 3, 4, 2 and 1 (each within the scatter of the next, the first and the last beyond it).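

In this assay, going by these compounds alone, the first matched pair of the series gives a 1.0-fold lower number from compound 2 to compound 4 (0.01 log units; within the scatter), so joining the same atoms differently, on a carbonyl carbon, makes no difference that can be read beyond the scatter. The earlier compounds shown here, which differ in more than one place, could not isolate this position. No measurement shown bears on why the two isomers read alike.

Still open, as far as these compounds go, is whether any group at this position moves the number beyond the scatter, for instance a simple phenyl ring carrying an amine or a carboxylic acid. This single pair also says nothing about a shorter chain on the piperidine nitrogen.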